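Swapping a hydroxypiperidine for a thiazolidinedione

The source may report more compounds than this note shows. Statements on the series, on what has been measured and on what is new or still open speak of the compounds shown alone.

Compound 1 `CN1CCN(C[C@H]2CN(c3ccc(-n4cc(-c5ccccn5)cn4)c(F)c3)C(=O)O2)CC1` gives 70 ug/mL in an ADME assay on HEK293-A cells (Homo sapiens) for cytotoxicity, read by MTT assay, with a stated time of 48 h; a higher number here means a weaker inhibitor, a lower number a stronger inhibitor.
Compound 2 `O=C1O[C@@H](CN2CCCCC2)CN1c1ccc(-n2cc(-c3ccccn3)cn2)c(F)c1` reaches only the limit of > 400 ug/mL in this assay.
Compound 3 `O=C1O[C@@H](CN2CCC(O)CC2)CN1c1ccc(-n2cc(-c3ccccn3)cn2)c(F)c1` likewise reaches only the limit of > 400 ug/mL in this assay.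

Compound 3 therefore stands at the limit of > 400 ug/mL in this assay, at which 2 of the 3 values shown sit, so its own number is not known, only that it lies past that limit. Compound 4 `O=C1CSC(=O)N1C[C@H]1CN(c2ccc(-n3cc(-c4ccccn4)cn3)c(F)c2)C(=O)O1` differs from it by 2,4-dioxo-1,3-thiazolidin-3-yl in place of 4-hydroxypiperidin-1-yl on a saturated chain carbon bound to a saturated ring carbon. For the measured compounds named here, no measured step touches this entering ring. The steps of an at least 5.7-fold higher number from compound 1 to compound 2 (0.75 log units; beyond the scatter) and an at least 5.7-fold higher number from compound 1 to compound 3 (0.75 log units; beyond the scatter) both remove the 4-methylpiperazin-1-yl group and both push the number up to the limit, while a step that the two limits leave unreadable from compound 2 to compound 3 cannot be read. With nothing pointing toward a stronger inhibitor, compound 4 is expected to sit again around the limit, at about 400 ug/mL (range 150 ug/mL to 1000 ug/mL). That expectation corresponds to a step of a number no higher from compound 3 to compound 4 (the limit leaves the size open).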

Compound 4, half-maximal inhibitory concentration: 283 ug/mL
Compound 4: the middle estimate sits 1.4-fold (0.15 log units) above what was measured; measured number inside the range.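

In this assay, 2,4-dioxo-1,3-thiazolidin-3-yl in place of 4-methylpiperazin-1-yl gives a 4.0-fold higher number from compound 1 to compound 4 (0.61 log units; beyond the scatter), the first rise from compound 1 at this position that can be read as a number rather than a floor. Against the piperidine rings, the result reads an at least 1.4-fold lower number from compound 3 to compound 4 (0.15 log units; that floor lies within the scatter) and an at least 1.4-fold lower number from compound 2 to compound 4 (0.15 log units; that floor lies within the scatter), so a real drop is not established. Those two steps are only floors: the limit of > 400 ug/mL in this assay, at which 2 of the 4 values shown sit.

The steps among compound 2, compound 3 and compound 4 therefore leave the true order of these three groups unreadable. From the compounds shown here alone, how a carboxylic acid or a longer chain at this place would behave also stays open.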